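A ring substitution at the amide carbonyl of compound 3

The source may hold more compounds than are shown below. What is called first, only, known or untested is meant among the compounds shown, and "the series" means these compounds.

Measured compounds:
compound 1 `CN(C)c1ccc(C(=O)Nc2cccc(NC(=O)COc3ccc4c(c3)CCC(=O)N4)c2)cc1` gives 9970 nM
compound 2 `COc1cc(OCC(=O)Nc2cccc(NC(=O)c3ccc(N(C)C)cc3)c2)ccc1C=O` gives 306 nM
compound 3 `O=C(COc1ccc2c(=O)ccoc2c1)Nc1cccc(NC(=O)c2ccccc2)c1` gives 16 nM

All three were tested in an assay on isolated protein for inhibition of Rho-associated protein kinase 2 (Homo sapiens), read by scintillation counting, radiometric assay and 33P incorporation, with a stated time of 40 min, in the presence of a further agent that is not named here; on this read-out higher numbers stand for weaker inhibition and lower numbers for stronger inhibition. On these numbers compound 3 stands lowest of the three; compound 2 lies nearest to it and compound 1 furthest, both gaps beyond the scatter. Within the data shown here, the only one-place step among the measured compounds is a 33-fold lower number from compound 1 to compound 2 (1.51 log units; beyond the scatter), and it concerns the group on an oxygen on a saturated carbon, not the amide end of the molecule. Among the measured compounds shown here, compound 2 and compound 3 differ in two places, so their values show only that compound 3 gives the lower number.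

For the measured compounds named here, compound 4 `Cc1cc(C(=O)Nc2cccc(NC(=O)COc3ccc4c(=O)ccoc4c3)c2)ccc1C(F)(F)F` has not yet been measured. a group of 11 heavy atoms (8 carbon, 3 fluorine; one six-membered aromatic ring of carbon only) in place of a group of 6 heavy atoms (6 carbon; one six-membered aromatic ring of carbon only), on a carbonyl carbon No measured step touches a carbonyl carbon whose other neighbour is an amide-type nitrogen, so there is no direct guide to the size of this change. Compound 4 is therefore expected to give a number close to that of compound 3, with a 1.6-fold higher number from compound 3 to compound 4 (0.19 log units; within the scatter) expected to stay within or only a little beyond the scatter. The estimate for compound 4 is 25 nM, with a range from 8 nM to 80 nM.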

Compound 4, half-maximal inhibitory concentration: 43 nM
Estimate against measurement, compound 4: 1.7-fold (0.24 log units) below; the measured number falls inside the stated range.
By their numbers in this assay, from the lowest: compound 3; then compound 4; then compound 2; then compound 1.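

Among these compounds, at the carbonyl carbon whose other neighbour is an amide-type nitrogen, putting the group of 11 heavy atoms (8 carbon, 3 fluorine) in place of phenyl gives, in this assay, a 2.7-fold higher number from compound 3 to compound 4 (0.43 log units; beyond the scatter), the first measured reading at this end of the molecule. The change is modest but beyond the scatter, and it is much smaller than a 33-fold lower number from compound 1 to compound 2 (1.51 log units; beyond the scatter), the step measured on an oxygen on a saturated carbon, so on these compounds the number moves less at the amide end, with the ring kept and its added atoms present. No measured information accounts for the direction or size of this step.

The entering group adds its carbon and fluorine atoms together, so this single step cannot show which of them accounts for the higher number, or whether either alone would give a change beyond the scatter. Going by these compounds, it also remains open how the number would respond to a carboxylic acid or a primary amine on the ring at this place, and whether a step here would be the same size on the core of compound 1.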